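The compounds below may be only part of what the source reports. "The series", "measured", "known", "first", "only" and "open" are said of these compounds alone.

In a functional assay on K562 cells (Homo sapiens) for inhibition, read by trypan blue exclusion, with a stated time of 72 h (a higher number here means a weaker inhibitor, a lower number a stronger inhibitor), compound 3 (`Cc1ccc(S(=O)(=O)c2cc3cnc(Nc4ccc5[nH]ccc5c4)nc3n(C)c2=O)cc1`) gives 750 nM and so stands second highest of the three numbers, with compound 1 (`Cn1c(=O)c(S(=O)(=O)c2ccc(O)cc2)cc2cnc(Nc3ccc4[nH]ccc4c3)nc21`) lower at 100 nM and compound 2 (`Cn1c(=O)c(S(=O)(=O)Nc2ccc(F)cc2)cc2cnc(Nc3ccc4[nH]ccc4c3)nc21`) higher at 5000 nM on that scale. Compound 4 (`Cn1c(=O)c(S(=O)(=O)c2ccc(N)cc2F)cc2cnc(Nc3ccc4[nH]ccc4c3)nc21`) has not yet been measured. It carries 4-amino-2-fluorophenyl in place of 4-methylphenyl on a sulfonyl sulfur. The measured step that bears most directly on this change is a 7.5-fold higher number from compound 1 to compound 3 (0.88 log units; beyond the scatter) with methyl in place of hydroxy on an aromatic carbon. For the measured compounds named here, compound 4 also lacks that methyl, but it has an amino group rather than hydroxy, and no measured compound carries either the amino group or the added fluorine. The other two steps, a 50-fold higher number from compound 1 to compound 2 (1.70 log units; beyond the scatter) and a 6.7-fold lower number from compound 2 to compound 3 (0.82 log units; beyond the scatter) in turn, show how far the number can move on changes at the sulfonyl sulfur. Both involve the (4-fluorophenyl)amino group of compound 2, which compound 4 lacks, so they bear on it less. A modest move towards a stronger inhibitor is therefore expected, and the estimate is a 3.0-fold lower number from compound 3 to compound 4 (0.48 log units; beyond the scatter) in this assay as its expected size. The estimate for compound 4 is 250 nM (expected range 60 nM to 1000 nM).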

Compound 4, half-maximal inhibitory concentration: 1500 nM
For compound 4 the middle estimate is 6.0-fold (0.78 log units) below the measured one, and the stated range ends below it.
By their numbers in this assay, from the lowest: compound 1; then compounds 3 and 4 (each within the scatter of the next); then compound 2.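

In this assay, a 2.0-fold higher number from compound 3 to compound 4 (0.30 log units; within the scatter), so 4-amino-2-fluorophenyl and 4-methylphenyl on a sulfonyl sulfur cannot be told apart here, and the low number of compound 1 does not carry over to the new aryl group: a 15-fold higher number from compound 1 to compound 4 (1.18 log units; beyond the scatter) leaves compound 1 the strongest inhibitor of the four. At the same time, a 3.3-fold lower number from compound 2 to compound 4 (0.52 log units; beyond the scatter) shows that 4-amino-2-fluorophenyl, like 4-methylphenyl, gives a stronger inhibitor than the (4-fluorophenyl)amino group of compound 2, which remains the weakest of the four, so among these compounds only the 4-hydroxyphenyl group of compound 1 stands apart at the top of the series. No measurement given here accounts for these differences.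

From the compounds shown here alone, since compound 4 brings in the amino group and the fluorine together, what each contributes alone stays open, and so does whether the fluorine offsets any gain from the amino group. Also open, going by these compounds, is whether the low number of compound 1 is specific to the hydroxy group or would persist with a methoxy group or a carboxylic acid at that place on the ring.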